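Swapping methyl for dimethylamino on a weak rat inhibitor

The source may hold more compounds than are shown below. What is called first, only, known or untested is meant among the compounds shown, and "the series" means these compounds.

Of the compounds shown here, three have been tested in a functional assay with Rattus norvegicus as the target; a higher number here means a weaker inhibitor, a lower number a stronger inhibitor. Compound 1, `CO/N=C(\C=C\c1ccncc1)c1cc(OC)c(OC)c(OC)c1`, gives only a limit in this assay, > 100000 nM, so no exact number is known for it. Compound 2, `N#Cc1ccc(C(=O)/C=C/c2ccncc2)cc1`, gives 123000 nM in this assay. Compound 3, `Cc1cccc(C(=O)/C=C/c2ccncc2)c1`, gives 39000 nM in this assay, the lowest of the two numbers shown, and its gap to compound 2 lies beyond the usual scatter. The one limit in the set is described as follows: the limit of > 100000 nM in this assay, at which 1 of the 3 values shown sits.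

Compound 4, `CN(C)c1cccc(C(=O)/C=C/c2ccncc2)c1`, has not yet been measured. It differs from compound 3 in one place: dimethylamino in place of methyl on an aromatic carbon. Within the data shown here, no step between two measured compounds mirrors this change, so the direction of its effect in this assay cannot be read from the existing numbers. The step from compound 3 to compound 4 in this assay is expected to be small, roughly a 1.3-fold lower number from compound 3 to compound 4 (0.11 log units; within the scatter), and it could fall on either side of no change. For compound 4 the estimated value in this assay is 30000 nM, with a likely range from 8000 nM to 120000 nM.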

Compound 4, half-maximal inhibitory concentration: 19000 nM
Beside the measured number, compound 4's estimate is 1.6-fold (0.20 log units) above it; the range from low to high includes it.
By their numbers in this assay, from the lowest: compound 4; then compound 3; then compound 2.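

In this assay, among these compounds, this is the first step between two measured compounds that differ in one place, and it reads a 2.1-fold lower number from compound 3 to compound 4 (0.31 log units; beyond the scatter). It shows that, on this aromatic carbon meta to a large group, the larger dimethylamino group can take the place of methyl with a modest move toward stronger inhibition, rather than a loss. No measurement shown here bears on the reason for this step.

On these data alone, it remains open whether other groups at this same place, such as a primary amine, a carboxylic acid or a longer chain like diethylamino, would lower the number further or raise it again. Also open, as far as these compounds go, is whether the same swap would give a similar step at another place on this ring or on a different core.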